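The source may report more compounds than this note shows. Statements on the series, on what has been measured and on what is new or still open speak of the compounds shown alone.

Compound 1 `COc1ccc2cc(C(C)c3nnc4n3N=C(c3ccc(OC(F)(F)F)cc3)CS4)ccc2c1` gives 16000 nM in a functional assay on Huh-7 cells (Homo sapiens) for inhibition, read by sulforhodamine B assay, with a stated time of 72 h; on this read-out higher numbers stand for weaker inhibition and lower numbers for stronger inhibition.
Compound 2 `COc1ccc2cc(C(C)c3nnc4n3N=C(c3ccc(Br)cc3)CS4)ccc2c1` gives 9300 nM in this assay.
Compound 3 `COc1ccc(C2=Nn3c(nnc3C(C)c3ccc4cc(OC)ccc4c3)SC2)cc1` gives 8500 nM in this assay.

Compound 3 holds the lowest of the three numbers, yet the gaps a 1.1-fold lower number from compound 2 to compound 3 (0.04 log units; within the scatter) and a 1.9-fold lower number from compound 1 to compound 3 (0.27 log units; within the scatter) both sit inside the scatter, so none of the three can be told apart. Compound 4 `COc1ccc2cc(C(C)c3nnc4n3N=C(c3ccc(C(F)(F)F)cc3)CS4)ccc2c1` carries trifluoromethyl in place of methoxy on an aromatic carbon. The closest guides are a 1.9-fold lower number from compound 1 to compound 3 (0.27 log units; within the scatter), where a trifluoromethoxy gave way to a methoxy, and a 1.1-fold lower number from compound 2 to compound 3 (0.04 log units; within the scatter), and also a 1.7-fold lower number from compound 1 to compound 2 (0.24 log units; within the scatter); none of these swaps at the same position moved the number beyond the scatter. Compound 4 is therefore expected to land near its neighbours, with an estimated step of a 1.4-fold higher number from compound 3 to compound 4 (0.15 log units; within the scatter). The expected value for compound 4 is 12000 nM, between 5000 nM and 30000 nM.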

Compound 4, half-maximal inhibitory concentration: 14800 nM
Beside the measured number, compound 4's estimate is 1.2-fold (0.09 log units) below it, and the stated range covers the measured number.
By their numbers in this assay, from the lowest: compounds 3, 2, 4 and 1 (each within the scatter of the next).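

Trifluoromethyl joins methoxy, bromo and trifluoromethoxy on this aromatic carbon, and in this assay it cannot be told apart from any of them: the steps read a 1.7-fold higher number from compound 3 to compound 4 (0.24 log units; within the scatter) against methoxy, a 1.6-fold higher number from compound 2 to compound 4 (0.20 log units; within the scatter) against bromo and a 1.1-fold lower number from compound 1 to compound 4 (0.03 log units; within the scatter) against trifluoromethoxy. Even a group counted with no hydrogen-bond acceptor, replacing methoxy with one, leaves the number within the scatter. Nothing available explains this flat result. Still open, from the compounds shown here alone, is whether an amine or a carboxylic acid at this position would move the number beyond the scatter.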